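Isopropylcarbonyl in place of acetyl on the pyrrolidine nitrogen

This account rests on a few compounds, and the source may have more. Where it says the series, first, only, none or still open, it means among the compounds named here.

Of the compounds shown here, three sharing one core have been measured in an assay on isolated protein for binding affinity to secreted frizzled-related protein 1 (Homo sapiens), read by fluorescence; a higher number here means a weaker inhibitor, a lower number a stronger inhibitor. Compound 1 `O=C(CN1CCCC1)N1CCC(NS(=O)(=O)c2cc(S(=O)(=O)c3ccccc3)ccc2C(F)(F)F)CC1` gives 110 nM. Compound 2 `CC(C)(C)OC(=O)N1CCC[C@@H]1C(=O)N1CCC(NS(=O)(=O)c2cc(S(=O)(=O)c3ccccc3)ccc2C(F)(F)F)CC1` gives 120 nM. Compound 3 `CC(=O)N1CCC[C@H]1C(=O)N1CCC(NS(=O)(=O)c2cc(S(=O)(=O)c3ccccc3)ccc2C(F)(F)F)CC1` gives 160 nM. The steps among them, a 1.1-fold higher number from compound 1 to compound 2 (0.04 log units; within the scatter), a 1.5-fold higher number from compound 1 to compound 3 (0.16 log units; within the scatter) and a 1.3-fold higher number from compound 2 to compound 3 (0.12 log units; within the scatter), all stay within the scatter, so compound 3 is not separated from either neighbour by more than repeated measurement would show.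

Compound 4 `CC(C)C(=O)N1CCC[C@H]1C(=O)N1CCC(NS(=O)(=O)c2cc(S(=O)(=O)c3ccccc3)ccc2C(F)(F)F)CC1` differs from compound 3 in one place: isopropyl in place of methyl on a carbonyl carbon. Within the data shown here, the step that bears most directly on this change is the one from the tert-butoxycarbonyl group to the acetyl group, a 1.3-fold higher number from compound 2 to compound 3 (0.12 log units; within the scatter), which exchanges a larger acyl group for a smaller one on the same nitrogen and barely moves this assay. Swapping acetyl for isopropylcarbonyl goes back toward a larger group, so no step beyond the scatter is expected in this assay, with at most a drift toward the number of compound 2.

Compound 4 is therefore expected at 140 nM, within 70 nM to 280 nM, an estimated step of a 1.1-fold lower number from compound 3 to compound 4 (0.06 log units; within the scatter).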

Compound 4, half-maximal inhibitory concentration: 40 nM
For compound 4 the middle estimate is 3.5-fold (0.54 log units) above the measured one, and the stated range ends above it.
By their numbers in this assay, from the lowest: compound 4; then compounds 1, 2 and 3 (each within the scatter of the next).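

In this assay, among these compounds, the group on the pyrrolidine nitrogen can move the number beyond the scatter after all: isopropyl in place of methyl on a carbonyl carbon gives a clear gain (a 4.0-fold lower number from compound 3 to compound 4 (0.60 log units; beyond the scatter)), a size of step that no earlier pair showed. The gain also sets compound 4 apart from the tert-butoxycarbonyl compound (a 3.0-fold lower number from compound 2 to compound 4 (0.48 log units; beyond the scatter)) and from the (pyrrolidin-1-yl)methyl compound (a 2.8-fold lower number from compound 1 to compound 4 (0.44 log units; beyond the scatter)), so compound 4 alone stands apart among these four, while the number does not simply follow the size of the acyl group, since compound 2 and compound 3 remain within the scatter of each other. Nothing available accounts for this step.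

Going by these compounds, whether the gain persists with cyclopropylcarbonyl, pivaloyl or a longer chain such as butanoyl remains open. So does the effect of the mirror-image 1-(isopropylcarbonyl)pyrrolidin-2-yl group, given that compound 2 carries the opposite configuration.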